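The compounds below may be only part of what the source reports. "The series", "measured", "known", "first", "only" and "open" are said of these compounds alone.

Measured so far: compound 1 `COC(=O)c1cccc(C(=O)N2CCCC(C(=O)Nc3ccc(Cl)cc3)C2)c1` gives 0% in an ADME assay on PC-3 cells (Homo sapiens) for cytotoxicity, read by WST assay, tested at 100 uM; a lower number here means less inhibition, a higher number more inhibition at the concentration tested (going by the name of the read-out); compound 2 `COc1cccc(NC(=O)C2CCCN(C(=O)c3cc(C(F)(F)F)cc(C(F)(F)F)c3)C2)c1` gives 0%; compound 3 `O=C(Nc1ccc(Cl)cn1)C1CCCN(C(=O)c2cc(C(F)(F)F)cc(C(F)(F)F)c2)C1` gives 0%.

Compound 1 stands level with compounds 2 and 3; none of the three registers in this assay beyond the scatter. Within the data shown here, the single recorded step, no change at the digits printed from compound 2 to compound 3 (within the scatter), changes a group on the amide-type nitrogen and leaves the read-out where it was.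

Compound 4 `O=C(Nc1ccc(Cl)cc1)C1CCCN(C(=O)c2cccc(-c3ccco3)c2)C1` differs from compound 1 by furan-2-yl in place of methoxycarbonyl on an aromatic carbon. Among the measured compounds shown here, no measured step touches that aromatic carbon, so the only guidance is that every variation seen so far stayed at the floor. Compound 4 is therefore expected to show no step beyond the scatter, a number 3 percentage points higher from compound 1 to compound 4 (within the scatter). The estimate for compound 4 is 3%, in the range -7% to 15%.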

Compound 4, a percentage reported as inhibition, at one concentration (the size of the read-out at that concentration, not a potency): 0%
Estimate against measurement, compound 4: 3 percentage points above; the range from low to high includes it.
By their numbers in this assay, from the lowest: compounds 1, 2, 3 and 4 (each within the scatter of the next).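

In this assay the aromatic carbon that carries methoxycarbonyl in compound 1 gets its first recorded step, and furan-2-yl in place of that group gives no change at the digits printed from compound 1 to compound 4 (within the scatter) and nothing more. A five-membered aromatic ring on this carbon thus leaves the read-out at the floor, just as the change on the amide-type nitrogen did. As far as these compounds go, whether an amine or a carboxylic acid on this aromatic carbon would lift the read-out remains open, as does whether any change to the shared core would. Nothing at hand offers an explanation for the unchanged read-out.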